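Hydroxy added to the ring of compound 3

The compounds below may be only part of what the source reports. "The series", "measured", "known", "first", "only" and "open" are said of these compounds alone.

Measured in an assay on HEK293 cells for inhibition of Monoacylglycerol lipase ABHD6 (Homo sapiens), read by fluorescence; a lower number here means a stronger inhibitor, a higher number a weaker inhibitor:
compound 1 `O=C(N1CCC=C[C@H]1Cc1ccccc1)n1cc(-c2ccc(-c3ccccc3)cc2)nn1`: 25.1 nM
compound 2 `O=C(N1CCC=C[C@@H]1COCc1ccccc1)n1cc(-c2ccc(-c3ccccc3)cc2)nn1`: 12.6 nM
compound 3 `O=C(N1CCC=C[C@H]1COCc1ccccc1)n1cc(-c2ccc(-c3ccccc3)cc2)nn1`: 100 nM

Compound 3 gives the highest number of the three, a 4.0-fold higher number from compound 1 to compound 3 (0.60 log units; beyond the scatter) and a 7.9-fold higher number from compound 2 to compound 3 (0.90 log units; beyond the scatter), the latter step resting on (the fact that compounds 2 and 3 differ only in the configuration as drawn). Compound 4 `O=C(N1C[C@H](O)C=C[C@H]1COCc1ccccc1)n1cc(-c2ccc(-c3ccccc3)cc2)nn1` differs from compound 3 by hydroxy in place of hydrogen on a saturated ring carbon. Within the data shown here, neither measured step concerns a hydroxy group or this ring carbon, so none bears on the change; the only guide is the value of compound 3 itself. The step of no change at the digits printed from compound 3 to compound 4 (within the scatter) is therefore expected to be none beyond the scatter, with wide uncertainty. Compound 4 is estimated at 100 nM, between 25 nM and 400 nM.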

Compound 4, half-maximal inhibitory concentration: 316 nM
Beside the measured number, compound 4's estimate is 3.2-fold (0.50 log units) below it; measured number inside the range.
By their numbers in this assay, from the lowest: compounds 2 and 1 (each within the scatter of the next); then compound 3; then compound 4.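

Hydroxy in place of hydrogen on the saturated ring carbon two ring bonds from the ring nitrogen gives a 3.2-fold higher number from compound 3 to compound 4 (0.50 log units; beyond the scatter) in this assay, so this position responds to substitution, and this change weakens inhibition here. The step is read only against the configuration of compound 3. No evidence shown bears on this step.

From the compounds shown here alone, whether compound 2, with the opposite configuration as drawn, responds in the same way stays open. A methoxy group, fluorine or an amine at this ring carbon would test whether the step is specific to hydroxy.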